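Three Analogues Measured, a Fourth Estimated

A few compounds are considered here, and "the series" means these few. Any claim that something is new, unique, unknown or untested is made for them only; others in the source may bear on it.

Three compounds that share one core were tested in an ADME assay on MT4 cells (Homo sapiens) for cytotoxicity, read by MTT assay, with a stated time of 4 days; on this read-out lower numbers stand for higher toxicity in this test and higher numbers for lower toxicity in this test. Compound 1 `CC(C)(C)c1ccc(/C(=N/O)c2ccnc(Nc3ccc(C#N)cc3)n2)cc1` gives 33700 nM in this assay. Compound 2 `N#Cc1ccc(Nc2nccc(/C(=N\O)c3cccc4ccccc34)n2)cc1` gives 33100 nM in this assay. Compound 3 `COc1cccc(/C(=N/O)c2ccnc(Nc3ccc(C#N)cc3)n2)c1` gives 30500 nM in this assay, the lowest of the three numbers, though its gaps to compound 2 and to compound 1 both lie within the usual scatter of this measurement, so the three cannot be put in order by it.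

Compound 4 `Cc1cc(C)cc(/C(=N/O)c2ccnc(Nc3ccc(C#N)cc3)n2)c1` has not yet been measured. It differs from compound 3 in one place: 3,5-dimethylphenyl in place of 3-methoxyphenyl on a carbon with a double bond to nitrogen. Among the measured compounds shown here, no step between two measured compounds that differ only in this way is available, so the size of the step has no precedent here. The three measured compounds, which carry different groups on the carbon with a double bond to nitrogen, all sit within the scatter of one another; on that basis the account expects no step beyond the scatter in this assay. Compound 4 is therefore estimated at 31000 nM in this assay, within a range from 15000 nM to 65000 nM. The step this estimate means, a 1.0-fold higher number from compound 3 to compound 4 (0.01 log units; within the scatter), is expected to stay inside the scatter.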

Compound 4, half-maximal cytotoxic concentration: 35900 nM
Beside the measured number, compound 4's estimate is 1.2-fold (0.06 log units) below it, and the stated range covers the measured number.
By their numbers in this assay, from the lowest: compounds 3, 2, 1 and 4 (each within the scatter of the next).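

In this assay, among the compounds shown here, this is the first step at this position with only one place changed: a 1.2-fold higher number from compound 3 to compound 4 (0.07 log units; within the scatter), when 3,5-dimethylphenyl replaces 3-methoxyphenyl on a carbon with a double bond to nitrogen. The earlier compounds shown here differed from one another in more than a single exchange of this kind, whereas here the hydrogen-bond acceptor of the 3-methoxyphenyl group is lost, the count of heavy atoms stays the same, and the number does not move beyond the scatter. No measurement at hand gives a reason for this result.

All four compounds shown carry an aromatic group on this carbon, so they leave open what an amine or a carboxylic acid in that place would do to the number. They also leave open whether a longer chain there would stay within the scatter of these four.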